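A fluoro swap on compound 3

The compounds below may be only part of what the source reports. "The series", "measured", "known", "first", "only" and "open" are said of these compounds alone.

In a functional assay on OCI-Ly3 cells (Homo sapiens) for antiproliferative activity (on this read-out lower numbers stand for an effect already at smaller amounts and higher numbers for an effect only at larger amounts of compound), compound 1 (`CC(C)c1c(NC(=O)Nc2cnc(-n3nccn3)c(Cl)c2)cnc2ccccc12`) gives 2420 nM, compound 2 (`O=C(Nc1cnc(-n2nccn2)c(Cl)c1)Nc1cnc2ccccc2c1C1CCCC1`) gives 7020 nM, and compound 3 (`CCOC(C)c1c(NC(=O)Nc2cnc(-n3nccn3)c(Cl)c2)cnc2ccccc12`) gives 1530 nM. The low end of this small set is therefore shared: the data show a 1.6-fold lower number from compound 1 to compound 3 (0.20 log units; within the scatter), but also a 4.6-fold lower number from compound 2 to compound 3 (0.66 log units; beyond the scatter).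

Compound 4 (`CCOC(C)c1c(NC(=O)Nc2cnc(-n3nccn3)c(Cl)c2)cnc2ccc(F)cc12`) keeps everything else and has fluoro in place of hydrogen on an aromatic carbon, in a six-membered aromatic ring of carbon only: fluoro in place of hydrogen on an aromatic carbon. Among the compounds with values here, no measured step touches that ring. All three change the group that is isopropyl in compound 1, and they stay modest, as with a 2.9-fold higher number from compound 1 to compound 2 (0.46 log units; beyond the scatter). They offer only a rough sense of how far a single change has moved the numbers in this set, and none shows what fluoro does here. With no evidence for a direction, no shift beyond the scatter is expected in this assay. The expected change is a 1.1-fold lower number from compound 3 to compound 4 (0.04 log units; within the scatter). For compound 4 the estimated value is 1400 nM, with an expected range from 600 nM to 3500 nM.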

Compound 4, half-maximal effective concentration: 590 nM
Compound 4: the middle estimate sits 2.4-fold (0.38 log units) above what was measured; measured number outside the range, below it.
By their numbers in this assay, from the lowest: compound 4; then compounds 3 and 1 (each within the scatter of the next); then compound 2.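

In this assay, fluoro in place of hydrogen gives a 2.6-fold lower number from compound 3 to compound 4 (0.41 log units; beyond the scatter), so a change at this aromatic carbon can move the number beyond the usual scatter. Within the data shown here, the earlier steps all altered the group that is isopropyl in compound 1, and this is the first to show that the six-membered aromatic ring of carbon only also matters, even though the change adds just one heavy atom. Nothing measured here explains why this swap lowers the number.

As far as these compounds go, it remains open whether chloro, methoxy or a nitrile on the same carbon would lower the number as well, or whether fluoro would do so on another carbon of this ring. From the compounds shown here alone, it is also open whether fluoro would have the same effect with isopropyl or cyclopentyl in place of the 1-ethoxyethyl group.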